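Three limits and a nitro analogue in cytotoxicity

The source may report more compounds than this note shows. Statements on the series, on what has been measured and on what is new or still open speak of the compounds shown alone.

Compounds measured in an ADME assay on HepG2 cells (Homo sapiens) for cytotoxicity, read by luminescence, with a stated time of 72 h; a lower number here means that less compound is needed, a higher number that more compound is needed for the effect:
Compound 1 `C=Cc1cccc(-c2[nH]c3cc(OC)ccc3c(=O)c2C(=O)OCC)c1` gives > 21500 nM, a limit of the assay.
Compound 2 `CCCCOc1cccc(-c2[nH]c3cc(OC)ccc3c(=O)c2C(=O)OCC)c1` gives > 21500 nM, likewise a limit.
Compound 3 `CCOC(=O)c1c(-c2cccc(C(F)(F)F)c2)[nH]c2cc(OC)ccc2c1=O` gives > 21500 nM, again a limit.

Compound 2 stands at the limit, as all three measured values do: the limit of > 21500 nM in this assay, at which 3 of the 3 values shown sit. The steps involving compound 2 are therefore unreadable, a step that the two limits leave unreadable from compound 1 to compound 2 and a step that the two limits leave unreadable from compound 2 to compound 3, and the same holds for a step that the two limits leave unreadable from compound 1 to compound 3. None of them shows a direction or a size.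

The unmeasured compound 4 `CCOC(=O)c1c(-c2cccc([N+](=O)[O-])c2)[nH]c2cc(OC)ccc2c1=O` differs from compound 2 by nitro in place of butoxy on an aromatic carbon. The measured steps that bear on this change, butoxy to vinyl and butoxy to trifluoromethyl, both end at the limit, so no step beyond the scatter can be read from them, in either direction, and the exchange of butoxy for nitro is expected to behave the same way. Compound 4 is expected to sit at about 25000 nM, within 12000 nM to 60000 nM, most probably reported again as a limit. This amounts to an expected step that the limit leaves unreadable from compound 2 to compound 4.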

Compound 4, half-maximal effective concentration: > 21500 nM
Compound 4: only a limit was reported (the forecaster's own chance of this, stated with the estimate: 85%); the middle value does not contradict the limit.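

In this assay compound 4 gives > 21500 nM as a limit of the assay. Among these compounds, no step among compound 1, compound 2, compound 3 and compound 4 can be read, as all four stand at the same limit: the limit of > 21500 nM in this assay, at which 4 of the 4 values shown sit. The compounds shown leave open how far each lies beyond that limit, and whether any of the four exchanged groups changes the value at all.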